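This account rests on a few compounds, and the source may have more. Where it says the series, first, only, none or still open, it means among the compounds named here.

Compound 1, `Cc1cccc(Oc2ccnc(N3CCC[C@H]3C(=O)NCc3cccnc3)n2)c1`: 4%
Compound 2, `Cc1cccc(Oc2ccnc(N3CCC[C@H]3C(=O)NCCCn3ccnc3)n2)c1`: 7%

Both numbers come from an assay on isolated protein for inhibition of high affinity nerve growth factor receptor (Homo sapiens), read by HTRF, tested at 10 uM (on this read-out higher numbers stand for more inhibition at the one concentration tested (going by the name of the read-out) and lower numbers for less inhibition), and both are small. The step of a number 3 percentage points higher from compound 1 to compound 2 (within the scatter) is within the scatter, so compound 1 and compound 2 cannot be told apart on this assay; compound 2 simply stands alongside compound 1, with nothing separating the two.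

Compound 3, `COC(=O)C(CO)NC(=O)[C@@H]1CCCN1c1nccc(Oc2cccc(C)c2)n1`, is the next compound to be measured. It differs from compound 2 in one place: 2-hydroxy-1-(methoxycarbonyl)ethyl in place of 3-(1H-imidazol-1-yl)propyl on an amide-type nitrogen. Among the compounds with values here, the only measured step that bears on this change is a number 3 percentage points higher from compound 1 to compound 2 (within the scatter), which also swapped the group on the amide-type nitrogen and stayed within the scatter. Nothing in the two measurements suggests that a different group at that position moves the inhibition much.

Compound 3 is therefore expected to give about 5%, between -8% and 18%. The expected step of a number 2 percentage points lower from compound 2 to compound 3 (within the scatter) is estimated to remain within the scatter.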

Compound 3, a percentage reported as inhibition, at one concentration (the size of the read-out at that concentration, not a potency): 4%
For compound 3 the middle estimate is 1 percentage points above the measured one; low and high end bracket the measured number.
By their numbers in this assay, from the lowest: compounds 1, 3 and 2 (each within the scatter of the next).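

Compound 3 puts 2-hydroxy-1-(methoxycarbonyl)ethyl on the amide-type nitrogen, a group with no ring, whereas 3-(1H-imidazol-1-yl)propyl and (pyridin-3-yl)methyl each carry an aromatic ring. In this assay this exchange gives a number 3 percentage points lower from compound 2 to compound 3 (within the scatter), and set against (pyridin-3-yl)methyl it gives no change at the digits printed from compound 1 to compound 3 (within the scatter). Within the data shown here, the earlier pair compared only two ring-bearing groups, so the finding that the three compounds cannot be told apart now also covers a group without a ring, one that carries a hydroxyl and a methoxycarbonyl. Still open, on these data alone, is whether an amine, a carboxylic acid or a longer alkyl chain on that nitrogen would give a number beyond the scatter, and whether a change elsewhere on the shared core would do so. No evidence is available that would account for these numbers.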